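Nitro to Acetamido on a Second Core: Cytotoxicity Outlook

The source may report more compounds than this note shows. Statements on the series, on what has been measured and on what is new or still open speak of the compounds shown alone.

Compound 1 `CC(=O)Nc1ccc(-c2nc3cc(C(F)(F)F)ccc3n2C2CCCCC2)cc1` and compound 2 `O=[N+]([O-])c1ccc(-c2nc3cc(C(F)(F)F)ccc3n2C2CCCCC2)cc1` share one core, while compound 3 `O=[N+]([O-])c1ccc(-c2nc3cc(Cl)c(Cl)cc3[nH]2)cc1` and the not yet measured compound 4 `CC(=O)Nc1ccc(-c2nc3cc(Cl)c(Cl)cc3[nH]2)cc1` share another; the difference between the two cores is not broken down here. All four belong to an ADME assay on MT4 cells (Homo sapiens) for cytotoxicity, read by MTT assay, with a stated time of 96 h; on this read-out higher numbers stand for lower toxicity in this test and lower numbers for higher toxicity in this test. In this assay compound 2 gives 49000 nM, and compound 1 gives 24000 nM. The change from compound 2 to compound 1 is acetamido in place of nitro on an aromatic carbon and it produced a 2.0-fold lower number from compound 2 to compound 1 (0.31 log units; beyond the scatter). Compound 3, which carries the nitro group on the other core, gives 17000 nM in this assay; that number sits within the scatter of the number for compound 1 and below the number for compound 2. Within the data shown here, compound 4 differs from compound 3 by acetamido in place of nitro on an aromatic carbon, which is the same change, at the same place, as the one from compound 2 to compound 1. For compound 4 the expected step in this assay is a 1.8-fold lower number from compound 3 to compound 4 (0.25 log units; within the scatter), about the size of the earlier one, because the same change gave a 2.0-fold lower number from compound 2 to compound 1 (0.31 log units; beyond the scatter) on the other core. Among the measured compounds shown here, only a single precedent exists, and that step lay just beyond the scatter, so the expectation is held loosely and given a wide range. Compound 4 is estimated at 9500 nM, between 4500 nM and 22000 nM.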

Compound 4, half-maximal cytotoxic concentration: > 100000 nM
Compound 4: only a limit was reported; the forecaster's own chance of this, stated with the estimate: 8%; at least 10-fold (1.02 log units) between middle value and limit.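

On the core of compound 3, acetamido in place of nitro on an aromatic carbon gave an at least 5.8-fold higher number from compound 3 to compound 4 (0.76 log units; beyond the scatter) in this assay, which runs opposite to the step seen on the core of compound 1. The change therefore did not carry from one core to the other in this test, and a step read on one core gave no reliable guide to the step on the other: the same change on two cores in this assay, a 2.0-fold lower number (0.31 log units; beyond the scatter) from compound 2 to compound 1 and an at least 5.8-fold higher number (0.76 log units; beyond the scatter) from compound 3 to compound 4, at least 12-fold (1.07 log units) apart, beyond the scatter of two such steps

For compound 4 only a limit of the assay was reported, > 100000 nM, so the direction of the step is known but its full size is not, and this pair of cores shows neither why the two steps part nor how the same change would behave on any further core.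

The compounds shown leave open how an amine or a longer acyl chain, placed on the same aromatic carbon para to a large group, would read on either core. They also leave open which part of the difference between the two cores goes with the parting of the two steps.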